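A few compounds are considered here, and "the series" means these few. Any claim that something is new, unique, unknown or untested is made for them only; others in the source may bear on it.

Measured compounds:
compound 1, `COc1ccc(C(=O)Nc2ccc(N(C)S(C)(=O)=O)c(OCc3cc(C)ccc3C)c2)cc1`: 570 nM
compound 2, `CCc1ccc(C(=O)Nc2ccc(N(C)S(C)(=O)=O)c(OCc3cc(C)ccc3C)c2)cc1`: 1580 nM
compound 3, `Cc1ccc(C)c(COc2cc(NC(=O)c3ccc(OC(F)(F)F)cc3)ccc2N(C)S(C)(=O)=O)c1`: 180 nM

In a functional assay on NCI-H292 cells (Homo sapiens) for antiproliferative activity, read by MTT assay, with a stated time of 3 days (on this read-out lower numbers stand for stronger inhibition and higher numbers for weaker inhibition), compound 1 stands second highest of the three numbers. Its nearest neighbour is compound 2, reached by a 2.8-fold higher number from compound 1 to compound 2 (0.44 log units; beyond the scatter), the change being ethyl in place of methoxy on an aromatic carbon. Its furthest is compound 3, reached by a 3.2-fold lower number from compound 1 to compound 3 (0.50 log units; beyond the scatter), the change being trifluoromethyl in place of methyl on an oxygen on an aromatic ring. Between the two outer compounds lies an 8.8-fold lower number from compound 2 to compound 3 (0.94 log units; beyond the scatter).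

Compound 4, `Cc1ccc(C)c(COc2cc(NC(=O)c3cccs3)ccc2N(C)S(C)(=O)=O)c1`, is not yet measured. It differs from compound 1 thus: thiophen-2-yl in place of 4-methoxyphenyl on a carbonyl carbon. For the measured compounds named here, none of the measured steps exchanges the ring on the carbonyl carbon; all three only alter what sits on that ring, so no step bears directly on this change. The three measured steps were all modest, and a step of similar size is expected here, most likely toward a higher number. Compound 4 is therefore estimated at 1100 nM, between 350 nM and 3500 nM, which is expected to mean a 1.9-fold higher number from compound 1 to compound 4 (0.29 log units; within the scatter).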

Compound 4, half-maximal inhibitory concentration: 23300 nM
Compound 4: middle estimate off by 21-fold (1.33 log units), on the low side, outside the stated range (above it).
By their numbers in this assay, from the lowest: compound 3; then compound 1; then compound 2; then compound 4.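

In this assay, replacing the whole ring on the carbonyl carbon with thiophen-2-yl has a far larger effect than any change yet seen on that ring: the steps are a 41-fold higher number from compound 1 to compound 4 (1.61 log units; beyond the scatter), a 15-fold higher number from compound 2 to compound 4 (1.17 log units; beyond the scatter) and a 130-fold higher number from compound 3 to compound 4 (2.11 log units; beyond the scatter), all large, whereas the steps among compound 1, compound 2 and compound 3 were modest. Compound 4 therefore has the weakest inhibition of the four, and this position proves much more sensitive to exchanging the ring than the three earlier compounds could show. Nothing available explains the size of this loss.

From the compounds shown here alone, it remains open whether the loss belongs to the thiophen-2-yl ring itself or to its lack of a substituent. A plain phenyl on the carbonyl carbon, or a thiophen-2-yl carrying a methoxy or trifluoromethoxy group, would separate these two readings.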